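Phenoxy in Place of Phenyl at a Second Position

The source may report more compounds than this note shows. Statements on the series, on what has been measured and on what is new or still open speak of the compounds shown alone.

Compound 2 `O=C(O)/C=C/c1ccc2noc(-c3ccc(-c4ccccc4)cc3)c2c1` and compound 1 `O=C(O)/C=C/c1ccc2noc(-c3ccc(Oc4ccccc4)cc3)c2c1` differ in a single place: phenoxy in place of phenyl on an aromatic carbon. In an assay for inhibition of inositol hexakisphosphate kinase 2 (Homo sapiens), read by colorimetric assay, coupled enzyme assay and malachite green, with a stated time of 120 min, in the presence of a further agent that is not named here (on this read-out higher numbers stand for weaker inhibition and lower numbers for stronger inhibition), compound 2 gives 74 nM and compound 1 gives 94 nM, so the step is a 1.3-fold higher number from compound 2 to compound 1 (0.10 log units; within the scatter). Compound 3 `O=C(O)c1ccc2noc(-c3cccc(-c4ccccc4)c3)c2c1` gives 130 nM in this assay; the difference between the core of compound 3 and the core of compound 2 is not broken down here. Compound 4 `O=C(O)c1ccc2noc(-c3cccc(Oc4ccccc4)c3)c2c1` has not yet been measured and differs from compound 3 by phenoxy in place of phenyl on an aromatic carbon. This is the same kind of change as from compound 2 to compound 1, but the place differs: there it was para to a large group, here it is meta to a large group. Because the earlier step of a 1.3-fold higher number from compound 2 to compound 1 (0.10 log units; within the scatter) stayed within the scatter, the step from compound 3 to compound 4 is expected to be about a 1.3-fold higher number from compound 3 to compound 4 (0.12 log units; within the scatter). Compound 4 is therefore estimated to give about 170 nM in this assay, most likely between 80 nM and 350 nM.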

Compound 4, half-maximal inhibitory concentration: 130 nM
For compound 4 the middle estimate is 1.3-fold (0.12 log units) above the measured one; the range from low to high includes it.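

In this assay, putting phenoxy in place of phenyl on the core of compound 3 gives no change at the digits printed from compound 3 to compound 4 (within the scatter). Set beside the earlier step, the result on the two cores does not differ: the same change on two cores in this assay, a 1.3-fold higher number (0.10 log units; within the scatter) from compound 2 to compound 1 and no change at the digits printed (within the scatter) from compound 3 to compound 4, 1.3-fold (0.10 log units) apart, within the scatter of two such steps. Within the data shown here, this shows that the change carried across these two cores with no difference beyond the scatter, but it rests on only two pairs, which also differ in where the group sits, and it does not show that the same would hold on any other core.

The compounds shown leave open how an amine or a longer alkyl chain would read in place of the phenyl or phenoxy group on either core. Going by these compounds, whether a methyl ester in place of the carboxylic acid would leave these numbers in the same range is also open.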